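The compounds below may be only part of what the source reports. "The series", "measured", "known", "first", "only" and "open" are said of these compounds alone.

Measured so far:
Compound 1, `Cc1c(C(=O)N/N=C\c2ccco2)oc2cccc(O)c12`: >= 40000 nM
Compound 2, `Cc1c(C(=O)N/N=C\c2cc(Cl)cc(Cl)c2O)oc2cccc(O)c12`: 9590 nM

Compound 1 carries a furan-2-yl group on the carbon that has a double bond to nitrogen. In a functional assay on PC-3 cells (Homo sapiens) for inhibition (on this read-out higher numbers stand for weaker inhibition and lower numbers for stronger inhibition), compound 1 gives only a limit of the assay, >= 40000 nM, so its true value is not known. Compound 2 carries a different ring in that place, and in this assay compound 2 gives 9590 nM. Compound 3, `Cc1c(C(=O)N/N=C\c2cccc(Br)c2O)oc2cccc(O)c12`, has not yet been measured. The change from compound 1 to compound 3 is 3-bromo-2-hydroxyphenyl in place of furan-2-yl on a carbon with a double bond to nitrogen. Because compound 1 sits at the limit of >= 40000 nM in this assay, at which 1 of the 2 values shown sits, its step to compound 3 cannot be given as a measured number. The step from compound 1 to compound 3 is expected to go toward stronger inhibition, roughly an at least 3.3-fold lower number from compound 1 to compound 3 (0.52 log units; beyond the scatter). Compound 3 is expected to give about 12000 nM in this assay, within a range from 3000 nM to 40000 nM.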

Compound 3, half-maximal inhibitory concentration: 16600 nM
Compound 3: the middle estimate sits 1.4-fold (0.14 log units) below what was measured, and the stated range covers the measured number.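

In this assay compound 1 gives >= 40000 nM, which is a limit of the assay and not a number. Placing 3-bromo-2-hydroxyphenyl instead of furan-2-yl on the carbon with a double bond to nitrogen gives the first step that can be read at this position, an at least 2.4-fold lower number from compound 1 to compound 3 (0.38 log units; beyond the scatter), and the true step may be larger because one end of it is only a limit: the limit of >= 40000 nM in this assay, at which 1 of the 3 values shown sits.

Both rings here that carry a hydroxy group and halogen give measured values, as compound 2 gives 9590 nM and compound 3 gives 16600 nM. The compounds shown leave open whether the hydroxy group, the bromine or the six-membered ring itself accounts for the step. A plain phenyl ring, or a phenyl ring bearing an amine, in this place would help to separate these parts.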